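A few compounds are considered here, and "the series" means these few. Any claim that something is new, unique, unknown or untested is made for them only; others in the source may bear on it.

Values in a functional assay on K562 cells (Homo sapiens) for inhibition, read by MTT assay, with a stated time of 72 h; on this read-out lower numbers stand for stronger inhibition and higher numbers for weaker inhibition:

compound 1 `CCc1ccc(C(=O)/C=C/C(=O)O)cc1`: 5530 nM
compound 2 `O=C(O)/C=C/C(=O)c1ccc(Cl)cc1`: 21700 nM

Among the two numbers measured so far in this assay, compound 2 holds the highest one. Going by the values given here, its nearest neighbour is compound 1, and the one measured step, a 3.9-fold higher number from compound 1 to compound 2 (0.59 log units; beyond the scatter), lies beyond the scatter.

Compound 3 `O=C(O)/C=C/C(=O)c1ccc(Cl)c(Cl)c1` is not yet measured. It differs from compound 2 by chloro in place of hydrogen on an aromatic carbon.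

Among the compounds with values here, none of the measured steps matches this change. Within the data shown here, the only step in hand, a 3.9-fold higher number from compound 1 to compound 2 (0.59 log units; beyond the scatter), exchanges one substituent for another on the ring and is a modest step; it does not show what a second chloro entering in place of hydrogen does. Among the measured compounds shown here, with no step of the same kind available, the expectation for compound 3 rests on the position of compound 2 alone, and the step of a 1.4-fold lower number from compound 2 to compound 3 (0.16 log units; within the scatter) is expected to stay within the scatter, with no direction that can be called out.

On that basis compound 3 is estimated at 15000 nM in this assay, with a range from 5000 nM to 45000 nM.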

Compound 3, half-maximal inhibitory concentration: 23200 nM
Estimate against measurement, compound 3: 1.5-fold (0.19 log units) below, within the range that was stated.
By their numbers in this assay, from the lowest: compound 1; then compounds 2 and 3 (each within the scatter of the next).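

In this assay, a second chloro in place of hydrogen, on the aromatic carbon ortho to a chloro group and meta to a group of 7 heavy atoms, gives a 1.1-fold higher number from compound 2 to compound 3 (0.03 log units; within the scatter). Until now the series held only an exchange of one substituent for another, a 3.9-fold higher number from compound 1 to compound 2 (0.59 log units; beyond the scatter), which lies beyond the scatter; this change instead adds one chlorine atom to the ring of compound 2, and the number in this assay stays within the scatter. This position therefore accepts a chloro with no readable change in the number, at least with the first chloro in place, and nothing in hand offers a reason for that.

It stays open whether this position is as indifferent to other groups, such as an amine, a methoxy group or a longer alkyl chain, since chloro is the only group shown there. As far as these compounds go, it also stays open whether the same chloro would leave the number unchanged with ethyl in place of the first chloro, as on compound 1, or with no other substituent on the ring.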